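A few compounds are considered here, and "the series" means these few. Any claim that something is new, unique, unknown or untested is made for them only; others in the source may bear on it.

Three compounds have been measured in a functional assay on MOLT-4 cells (Homo sapiens) for inhibition; a lower number here means a stronger inhibitor, a higher number a weaker inhibitor:

compound 1, `O=C1/C(=C/c2ccc(Cl)cc2)CCCc2ccccc21`: 33000 nM
compound 2, `O=C1/C(=C/c2ccc(Br)cc2)CCCc2ccccc21`: 54700 nM
compound 3, `O=C1CCCCC/C1=C\c1cccc(Cl)c1`: 88600 nM

Compound 2 differs from compound 1 by bromo in place of chloro on an aromatic carbon, and that step gave a 1.7-fold higher number from compound 1 to compound 2 (0.22 log units; within the scatter). Compound 3 has a different core; the difference between the core of compound 1 and the core of compound 3 is not broken down here. Compound 4, `O=C1CCCCC/C1=C\c1cccc(Br)c1`, is not yet measured and differs from compound 3 by bromo in place of chloro on an aromatic carbon. This is the same kind of change as the one from compound 1 to compound 2, occurring twice among these compounds, but the surroundings differ: in the first pair the place is para to a large group, in the second it is meta to a group of 9 heavy atoms. In this assay, the step of a 1.5-fold higher number from compound 3 to compound 4 (0.17 log units; within the scatter) is expected, resting on the earlier step of a 1.7-fold higher number from compound 1 to compound 2 (0.22 log units; within the scatter). Compound 4 is therefore estimated at 130000 nM, between 60000 nM and 300000 nM.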

Compound 4, half-maximal inhibitory concentration: 176000 nM
For compound 4 the middle estimate is 1.4-fold (0.13 log units) below the measured one, within the range that was stated.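

Putting bromo in place of chloro gave a 2.0-fold higher number from compound 3 to compound 4 (0.30 log units; within the scatter) in this assay. Set beside the earlier step, the change reads much the same on both cores: the same change on two cores in this assay, a 1.7-fold higher number (0.22 log units; within the scatter) from compound 1 to compound 2 and a 2.0-fold higher number (0.30 log units; within the scatter) from compound 3 to compound 4, 1.2-fold (0.08 log units) apart, within the scatter of two such steps. This shows that the step carried over between these two pairs, but each step lies within the scatter, so neither pair establishes a real difference between bromo and chloro, and two pairs say nothing about other cores in the series.

What the compounds shown leave open is how groups of another kind, such as an amine or a carboxylic acid, would behave at this place. On these data alone, it also remains open whether such a swap would carry between the two cores as this one does.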